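The compounds below may be only part of what the source reports. "The series", "measured", "known", "first", "only" and "open" are said of these compounds alone.

Measured compounds:
- compound 1, `CCC1C(=O)N(C)c2cnc(-n3ccnc3-c3ccc(F)cc3)nc2N1C1CCC(F)(F)C1`: 13 nM
- compound 2, `CC[C@@H]1C(=O)N(C)c2cnc(-c3cn[nH]c3-c3ccc(F)cc3F)nc2N1c1cnn(C)c1`: 103 nM

In an assay on isolated protein for inhibition of serine/threonine-protein kinase PLK2 (Homo sapiens), read by TR-FRET, with a stated time of 60 min (on this read-out higher numbers stand for weaker inhibition and lower numbers for stronger inhibition), compound 1 gives 13 nM, the lower of the two numbers recorded so far; compound 2 gives 103 nM, a gap beyond the usual scatter. The two differ in several places at once, so no single change can be read from them.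

Compound 3, `CCC1C(=O)N(C)c2cnc(-n3ccnc3-c3ccc(F)cc3)nc2N1c1ccc(C#N)cc1`, is not yet measured. It differs from compound 1 in one place: 4-cyanophenyl in place of 3,3-difluorocyclopentyl on a nitrogen on an aromatic ring in a ring

Among the compounds with values here, no measured pair shows this change in isolation. Compound 2, which also carries an aromatic ring on that nitrogen, gives the weaker value 103 nM, but it differs from compound 1 elsewhere too, so this is weak guidance. A modest step toward weaker inhibition, expected to be a 2.3-fold higher number from compound 1 to compound 3 (0.36 log units; beyond the scatter), seems plausible, though one within the scatter cannot be ruled out. Compound 3 is therefore expected to give about 30 nM in this assay, with a range from 8 nM to 120 nM.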

Compound 3, half-maximal inhibitory concentration: 31 nM
Beside the measured number, compound 3's estimate is 1.0-fold (0.01 log units) below it, within the range that was stated.
By their numbers in this assay, from the lowest: compound 1; then compound 3; then compound 2.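

In this assay, within the data shown here, putting 4-cyanophenyl in place of 3,3-difluorocyclopentyl on the nitrogen next to the ring atom that bears an ethyl group gives a 2.4-fold higher number from compound 1 to compound 3 (0.38 log units; beyond the scatter), the first reading of a single change at this position. Within this pair, the position accepts a six-membered aromatic ring carrying a nitrile in place of a five-membered non-aromatic ring carrying two fluorines, at the cost of only a modest step toward weaker inhibition. No measurement here explains the size of that step.

The compounds shown leave open whether the step follows from the change of ring or from the nitrile, which a plain phenyl or an unfluorinated cyclopentyl on the same nitrogen would help separate. They also leave open whether the step would hold on the core of compound 2, with its other groups.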